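The source may report more compounds than this note shows. Statements on the series, on what has been measured and on what is new or still open speak of the compounds shown alone.

- compound 1 `COc1cc2c(cc1CCC(C)C)C(=O)C[C@@H](c1ccc(O)cc1)O2`: 77%
- compound 2 `COc1cc2c(cc1CC=C(C)C)C(=O)C[C@@H](c1ccc(Oc3ccc(F)cc3)cc1)O2`: 29%

Going by the values given here, in a functional assay on HCT-116 cells (Homo sapiens) for inhibition, read by sulforhodamine B assay, with a stated time of 48 h, tested at 50 uM (on this read-out higher numbers stand for more inhibition of growth at the one concentration tested and lower numbers for less inhibition of growth), compound 2 gives 29%, the lower of the two numbers so far. Compound 1 gives 77%, and this gap lies beyond the usual scatter. However, these two compounds differ in more than one place, so their gap cannot be tied to any single change.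

Compound 3 `COc1cc2c(cc1CC=C(C)C)C(=O)C[C@@H](c1ccc(Oc3ccccc3)cc1)O2` differs from compound 2 in one place: hydrogen in place of fluoro on an aromatic carbon. This is hydrogen in place of fluoro on an aromatic carbon, turning 4-fluorophenoxy into phenoxy. Among the compounds with values here, no measured pair shows this change, so the best guide is compound 2 at 29%. The expected result is no step beyond the scatter, with the estimate being a number 3 percentage points higher from compound 2 to compound 3 (within the scatter). For compound 3, the expected value is 32%, with an estimated range of 15% to 50%.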

Compound 3, percent growth inhibition at one concentration: 76%
Compound 3: the middle estimate sits 44 percentage points below what was measured; measured number outside the range, above it.
By their numbers in this assay, from the lowest: compound 2; then compounds 3 and 1 (each within the scatter of the next).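

Swapping fluoro for hydrogen on an aromatic carbon, para to a large group, gives in this assay a number 47 percentage points higher from compound 2 to compound 3 (beyond the scatter). Going by these compounds alone, this is the first pair that differs in one place only, so unlike the gap between compound 1 and compound 2, this step can be tied to a single change, and it shows that one fluorine atom at this position is enough to move growth inhibition far at the one concentration tested. Nothing measured here explains why this single atom has so large an effect.

Going by these compounds, it remains open whether another group at this place, such as chloro, methoxy or an amine, would read like hydrogen or like fluoro. On these data alone, it is also open whether the same swap would give a step of similar size with the saturated side chain of compound 1.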